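This account rests on a few compounds, and the source may have more. Where it says the series, first, only, none or still open, it means among the compounds named here.

In a functional assay on A549 cells (Homo sapiens) for antiproliferative activity, read by spectrophotometry, with a stated time of 2 days (on this read-out higher numbers stand for weaker inhibition of growth and lower numbers for stronger inhibition of growth), compound 1 (`Cc1cc(C)cc(Nc2ncc(C(F)(F)F)c(N3Cc4cccc(N(C)S(C)(=O)=O)c4C3)n2)c1`) gives > 30000 nM, which is a limit of the assay and not a number. Compound 2 (`CN(c1cccc2c1CN(c1nc(Nc3cccc(C(F)(F)F)c3)ncc1C(F)(F)F)C2)S(C)(=O)=O`) gives > 30000 nM, also a limit. Among the compounds with values here, the only measured step, a step that the two limits leave unreadable from compound 1 to compound 2, therefore offers no size to carry forward, and the limit of > 30000 nM in this assay, at which 2 of the 2 values shown sit, is all that bears on the next change. Compound 3 (`CN(c1cccc2c1CN(c1nc(Nc3cc(Cl)cc(C(F)(F)F)c3)ncc1C(F)(F)F)C2)S(C)(=O)=O`) has chloro in place of hydrogen on an aromatic carbon, meta to a trifluoromethyl group: chloro in place of hydrogen on an aromatic carbon. No clear gain in this assay is expected because of the limit of > 30000 nM in this assay, at which 2 of the 2 values shown sit. The expected size is a number no higher from compound 2 to compound 3 (the limit leaves the size open). For compound 3 the estimate is 30000 nM, with an expected range of 10000 nM to 60000 nM.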

Compound 3, concentration for 50% growth inhibition: 6700 nM
Estimate against measurement, compound 3: 4.5-fold (0.65 log units) above, outside the stated range (below it).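

In this assay, chloro on an aromatic carbon, meta to a trifluoromethyl group, gives an at least 4.4-fold lower number from compound 2 to compound 3 (0.65 log units; beyond the scatter) and so shows that this ring position can move the read-out off the limit. The 3-chloro-5-(trifluoromethyl)phenyl group in place of 3,5-dimethylphenyl gives an at least 4.4-fold lower number from compound 1 to compound 3 (0.65 log units; beyond the scatter) on the same core, whereas the step from compound 1 to compound 2 cannot be read. The other two values are limits of the assay, not numbers: the limit of > 30000 nM in this assay, at which 2 of the 3 values shown sit.

The compounds shown leave open whether bromo, methoxy or a nitrile at this place would do the same as chloro. They also leave open whether chloro would give a step with a methyl group in place of the trifluoromethyl group.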